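Halogenated benzyl ethers on the shared core: toward difluoro

The compounds below may be only part of what the source reports. "The series", "measured", "known", "first", "only" and "open" are said of these compounds alone.

Three compounds on the same core are in hand. Compound 1 `N[C@]1(C(=O)O)[C@H]2[C@@H](C[C@H]1OCc1ccccc1Cl)[C@]2(F)C(=O)O` gives 4.99 nM in an assay on CHO cells for binding affinity to metabotropic glutamate receptor 2 (Rattus norvegicus); on this read-out lower numbers stand for stronger inhibition and higher numbers for weaker inhibition. Compound 2 `N[C@]1(C(=O)O)[C@H]2[C@@H](C[C@H]1OCc1cccc(Cl)c1)[C@]2(F)C(=O)O` gives 3.28 nM in this assay, and compound 3 `N[C@]1(C(=O)O)[C@H]2[C@@H](C[C@H]1OCc1cccc(Br)c1)[C@]2(F)C(=O)O` gives 4.71 nM in this assay. All three numbers lie within the scatter of one another: a 1.5-fold lower number from compound 1 to compound 2 (0.18 log units; within the scatter), a 1.1-fold lower number from compound 1 to compound 3 (0.03 log units; within the scatter) and a 1.4-fold higher number from compound 2 to compound 3 (0.16 log units; within the scatter). Compound 3 therefore stands with the other two, not apart from them.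

Compound 4 `N[C@]1(C(=O)O)[C@H]2[C@@H](C[C@H]1OCc1ccc(F)c(F)c1)[C@]2(F)C(=O)O` is not yet measured. The change from compound 3 to compound 4 is 3,4-difluorophenyl in place of 3-bromophenyl on a saturated chain carbon bound to an oxygen on a saturated carbon. Going by the values given here, the steps that bear on it are the ones that alter the halogen or its placement on the phenyl ring, a 1.4-fold higher number from compound 2 to compound 3 (0.16 log units; within the scatter) and a 1.5-fold lower number from compound 1 to compound 2 (0.18 log units; within the scatter), both within the scatter. Among the compounds with values here, no step exceeding the scatter has been seen for any exchange on this ring, so for compound 4 a step of the same kind is expected in this assay, that is, a 1.0-fold lower number from compound 3 to compound 4 (0.02 log units; within the scatter), with no direction claimed beyond the scatter. The estimate for compound 4 is 4.5 nM, with a range from 2 nM to 10 nM.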

Compound 4, inhibition constant: 2.27 nM
The estimate for compound 4 lay 2.0-fold (0.30 log units) above the measured number; the measured number falls inside the stated range.
By their numbers in this assay, from the lowest: compounds 4, 2, 3 and 1 (each within the scatter of the next, the first and the last beyond it).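

In this assay, going by these compounds alone, this place, on a saturated chain carbon bound to an oxygen on a saturated carbon, gives its first steps beyond the scatter: a 2.1-fold lower number from compound 3 to compound 4 (0.32 log units; beyond the scatter) and a 2.2-fold lower number from compound 1 to compound 4 (0.34 log units; beyond the scatter), both modest, where no exchange among the earlier compounds left the scatter. The 3,4-difluorophenyl group does not stand apart from every earlier ring, however: a 1.4-fold lower number from compound 2 to compound 4 (0.16 log units; within the scatter), so the 3-chlorophenyl group goes against any general gain for this change. Nothing at hand bears on why the steps fall as they do.

Open, as far as these compounds go, is whether a single fluoro group on the phenyl ring would stand with 3,4-difluorophenyl or with 3-bromophenyl. Also open, from the compounds shown here alone, is how a non-halogen group on this ring, such as methoxy, a nitrile or a carboxylic acid, would read out.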